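The source may hold more compounds than are shown below. What is called first, only, known or untested is meant among the compounds shown, and "the series" means these compounds.

For the measured compounds named here, in a functional assay on MDA-MB-231 cells (Homo sapiens) for cytotoxicity, read by ELISA, with a stated time of 2 days (on this read-out higher numbers stand for weaker inhibition and lower numbers for stronger inhibition), compound 3 (`Oc1ccc(-c2cc(-c3ccccc3)nc(-c3ccco3)c2)cc1`) gives 1000 nM, the lowest number of the three measured so far. Compound 1 (`Oc1cccc(-c2cc(-c3ccccc3)nc(-c3ccco3)c2)c1`) gives 20800 nM, and compound 2 (`Oc1cccc(-c2cc(-c3ccccc3)nc(-c3ccncc3)c2)c1`) gives 12200 nM. Compound 4 (`Oc1ccc(-c2cc(-c3ccccc3)nc(-c3ccncc3)c2)cc1`) differs from compound 3 by a single change, pyridin-4-yl in place of furan-2-yl on an aromatic carbon. The same exchange has been measured once, with a 3-hydroxyphenyl group in the molecule: a 1.7-fold lower number from compound 1 to compound 2 (0.23 log units; within the scatter), which lies within the scatter. The other measured step, a 21-fold lower number from compound 1 to compound 3 (1.32 log units; beyond the scatter), is large, but it concerns 4-hydroxyphenyl in place of 3-hydroxyphenyl and leaves the furan-2-yl group untouched. Going by the values given here, it shows that the hydroxyphenyl group can matter, and no measured pair tests the exchange with a 4-hydroxyphenyl group, so the range is kept wide. No step beyond the scatter is therefore expected in this assay. The expected change is a 1.3-fold lower number from compound 3 to compound 4 (0.10 log units; within the scatter). Compound 4 is estimated at 800 nM, with an expected range of 300 nM to 2500 nM.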

Compound 4, half-maximal inhibitory concentration: 2100 nM
For compound 4 the middle estimate is 2.6-fold (0.42 log units) below the measured one; the range from low to high includes it.
By their numbers in this assay, from the lowest: compound 3; then compound 4; then compounds 2 and 1 (each within the scatter of the next).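

With a 4-hydroxyphenyl group in the molecule, pyridin-4-yl in place of furan-2-yl next to the ring nitrogen in this assay gives a 2.1-fold higher number from compound 3 to compound 4 (0.32 log units; beyond the scatter), a modest step, so this exchange does not stay within the scatter on every core. Its outcome differs with the hydroxyphenyl group present: the same change on two cores in this assay, a 1.7-fold lower number (0.23 log units; within the scatter) from compound 1 to compound 2 and a 2.1-fold higher number (0.32 log units; beyond the scatter) from compound 3 to compound 4, 3.6-fold (0.55 log units) apart, beyond the scatter of two such steps. 4-Hydroxyphenyl in place of 3-hydroxyphenyl also gives a lower number with pyridin-4-yl, a 5.8-fold lower number from compound 2 to compound 4 (0.76 log units; beyond the scatter), but the size of that step differs with the group at this position: the same change on two cores in this assay, a 21-fold lower number (1.32 log units; beyond the scatter) from compound 1 to compound 3 and a 5.8-fold lower number (0.76 log units; beyond the scatter) from compound 2 to compound 4, 3.6-fold (0.55 log units) apart, beyond the scatter of two such steps.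

For the compounds shown here, these four compounds cover only two groups at this position and two hydroxyphenyl groups, so it remains open whether this dependence extends to other groups. Also open, on these data alone, is how an amine or a carboxylic acid in place of furan-2-yl, or a methoxy group in place of the hydroxyl, would read.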